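The source may report more compounds than this note shows. Statements on the series, on what has been measured and on what is new or still open speak of the compounds shown alone.

Measured so far:
compound 1 `Cc1cc(S(=O)(=O)/N=C(\N)n2nccc2-c2ccccc2)c(SCc2cccc(Cl)c2)cc1Cl` — 0.309 h
compound 2 `Cc1cc(-c2ccccc2)n(/C(N)=N/S(=O)(=O)c2cc(C)c(Cl)cc2SCc2ccccc2C)n1` — 0.154 h

In an ADME assay on microsomes from liver (Homo sapiens) for metabolic stability, read by LC-MS, using NADPH, tested at 5 uM (on this read-out higher numbers stand for a longer-lived compound and lower numbers for a shorter-lived compound), compound 2 gives 0.154 h, and compound 1 gives 0.309 h, the two numbers sitting within the usual scatter of each other. Compound 3 `Cc1cc(S(=O)(=O)/N=C(\N)n2nccc2-c2ccccc2)c(SCc2ccccc2C)cc1Cl` awaits measurement. It differs from compound 2 by hydrogen in place of methyl on an aromatic carbon. Within the data shown here, no step of this kind between measured compounds is available, so the expectation rests on the closeness of compound 1 and compound 2. The step of a 1.3-fold higher number from compound 2 to compound 3 (0.11 log units; within the scatter) is expected to be small, in either direction, not beyond the scatter. Compound 3 is therefore estimated at 0.2 h, with a range from 0.1 h to 0.42 h.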

Compound 3, half-life: 0.0802 h
Compound 3: middle estimate off by 2.5-fold (0.40 log units), on the high side; measured number below the stated range.
By their numbers in this assay, from the lowest: compounds 3, 2 and 1 (each within the scatter of the next, the first and the last beyond it).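

In this assay hydrogen in place of methyl on an aromatic carbon of the five-membered aromatic ring with 2 nitrogen leaves the half-life within the scatter (a 1.9-fold lower number from compound 2 to compound 3 (0.28 log units; within the scatter)), so this position shows no clear response to this change. Among these compounds, with that methyl absent, 2-methylphenyl in place of 3-chlorophenyl on a saturated chain carbon bound to a sulfur gives the first single-place step beyond the scatter (a 3.9-fold lower number from compound 1 to compound 3 (0.59 log units; beyond the scatter)). Nothing given here accounts for either step. From the compounds shown here alone, whether an ethyl, a methoxy or an amine on that aromatic carbon would give a step beyond the scatter stays open. So does how a carboxylic acid there would read in this assay.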